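The source may hold more compounds than are shown below. What is called first, only, known or untested is meant among the compounds shown, and "the series" means these compounds.

Compound 3 `CN(C[C@@H]1CCCc2cc(S(=O)(=O)c3cccc(F)c3)ccc21)C(N)=O` stands at the top of the three numbers measured in an assay on isolated protein for displacement of a labelled ligand from 5-hydroxytryptamine receptor 6 (Homo sapiens) (a lower number here means a stronger inhibitor, a higher number a weaker inhibitor), where compound 3 gives 39.8 nM. Its nearest neighbour is compound 1 `CN(CC(N)=O)C[C@@H]1CCCc2cc(S(=O)(=O)c3cccc(F)c3)ccc21`, which in this assay gives 1.26 nM; the step of a 32-fold higher number from compound 1 to compound 3 (1.50 log units; beyond the scatter) turns on carbamoyl in place of carbamoylmethyl on the amine nitrogen. Furthest away is compound 2 `O=S(=O)(c1cccc(F)c1)c1ccc2c(c1)CCC[C@H]2CNCCO`, which in this assay gives 0.126 nM; the step of a 320-fold higher number from compound 2 to compound 3 (2.50 log units; beyond the scatter) exchanges the whole side chain, and a 10-fold lower number from compound 1 to compound 2 (1.00 log units; beyond the scatter) shows how far the (2-hydroxyethyl)amino chain lies from the carbamoylmethyl one. Compound 4 `CC(=O)N(C)C[C@@H]1CCCc2cc(S(=O)(=O)c3cccc(F)c3)ccc21` keeps the side chain of compound 3 and differs only at the carbonyl: methyl in place of amino on a carbonyl carbon. None of the three measured steps tests this replacement directly. Among the measured compounds shown here, the two steps that end at compound 3 both arrive at the weakest number from chains carrying either a hydroxyl or a primary amide, so the set offers no precedent for an acetyl group; the nearest comparison, a 32-fold higher number from compound 1 to compound 3 (1.50 log units; beyond the scatter), was large. The expectation is therefore a modest step in this assay, its direction uncertain, leaning toward a somewhat higher number. For compound 4 the estimate in this assay is 60 nM, with a range from 12 nM to 300 nM. That corresponds to an expected step of a 1.5-fold higher number from compound 3 to compound 4 (0.18 log units; within the scatter).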

Compound 4, inhibition constant: 1.59 nM
Estimate against measurement, compound 4: 38-fold (1.58 log units) above, and the stated range ends above it.
By their numbers in this assay, from the lowest: compound 2; then compounds 1 and 4 (each within the scatter of the next); then compound 3.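

In this assay, the carbonyl carbon bearing the amide-type nitrogen proves highly sensitive to a single replacement: methyl in place of amino gives a 25-fold lower number from compound 3 to compound 4 (1.40 log units; beyond the scatter), so the high number of compound 3 does not extend to every carbonyl group on that nitrogen. The acetyl and carbamoylmethyl groups on the amine nitrogen cannot be told apart, since a 1.3-fold higher number from compound 1 to compound 4 (0.10 log units; within the scatter) stays within the scatter, while the (2-hydroxyethyl)amino chain keeps a clear lead, with a 13-fold higher number from compound 2 to compound 4 (1.10 log units; beyond the scatter). Nothing available here accounts for the size of the amino-to-methyl step.

The compounds shown leave open how far this carbonyl carbon tolerates other groups, such as ethyl, methoxy or dimethylamino, and so whether the carbamoyl group is an isolated exception or one end of a wider trend. They also leave open what the methyl on the amide-type nitrogen contributes, a question that an acetylamino chain carrying hydrogen on that nitrogen would address.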